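Compound 3 to compound 4: replacing the hydroxy

The compounds below may be only part of what the source reports. "The series", "measured", "known", "first", "only" and "open" are said of these compounds alone.

In a functional assay on MCF7 cells (Homo sapiens) for inhibition, read by sulforhodamine B assay, with a stated time of 72 h (on this read-out lower numbers stand for stronger inhibition of growth and higher numbers for weaker inhibition of growth), compound 1 `CNC(=O)/C=C/c1ccncc1-c1ccc2ccccc2c1` gives 9340 nM and compound 2 `CCOC(=O)/C=C/c1ccncc1-c1ccc2ccccc2c1` gives 8320 nM. Both share one core and differ only in the group on the carbonyl carbon. Compound 3 `O=C(O)/C=C/c1ccncc1-c1ccc2ccccc2c1` carries a hydroxy there and gives > 10000 nM, which is a limit of the assay and not a number. Compound 3 thus offers no exact starting point.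

Compound 4 `COC1CN(C(=O)/C=C/c2ccncc2-c2ccc3ccccc3c2)C1` has 3-methoxyazetidin-1-yl in place of hydroxy on a carbonyl carbon.

Three measured steps change this same group. Putting ethoxy in place of methylamino gives a 1.1-fold lower number from compound 1 to compound 2 (0.05 log units; within the scatter). Putting hydroxy in place of methylamino gives an at least 1.0-fold higher number from compound 1 to compound 3 (0.02 log units; that floor lies within the scatter). Putting hydrogen in place of ethyl on the oxygen gives an at least 1.2-fold higher number from compound 2 to compound 3 (0.07 log units; that floor lies within the scatter). None of these steps is shown to exceed the scatter, yet none tested a group as large as the new one, so the comparison is only a rough guide. A small change is therefore expected, with no clear shift beyond the scatter in either direction, and another limit result is possible.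

The estimate amounts to an at least 1.2-fold lower number from compound 3 to compound 4 (0.09 log units; that floor lies within the scatter). For compound 4 the expected value is 8000 nM, with an estimated range from 3000 nM to 10000 nM.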

Compound 4, concentration for 50% growth inhibition: > 10000 nM
Compound 4: a limit, no number; the forecaster's own chance of this, stated with the estimate: 40%; middle value at least 1.2-fold (0.09 log units) from the limit.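

In this assay compound 4 gives > 10000 nM, which is a limit of the assay and not a number. Measured against the two exact values, the new group gives an at least 1.2-fold higher number from compound 2 to compound 4 (0.07 log units; that floor lies within the scatter) and an at least 1.0-fold higher number from compound 1 to compound 4 (0.02 log units; that floor lies within the scatter), so a group as large as 3-methoxyazetidin-1-yl, with its four-membered ring and no hydrogen-bond donor, shows no gain in growth inhibition over the small methylamino and ethoxy groups on this carbonyl carbon. The step from compound 3 to compound 4 cannot be read, since both ends are limits, but exchanging the hydroxy, with its hydrogen-bond donor, for this larger group did not bring a number within the assay's range, and the result now rests on this shared limit: the limit of > 10000 nM in this assay, at which 2 of the 4 values shown sit.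

Going by these compounds, how far compound 3 and compound 4 lie past the limit stays open, and so does whether they differ at all. Also open, on these data alone, is whether a dimethylamino group, a morpholine ring or a longer chain ending in an amine on the same carbonyl carbon would shift the number beyond the scatter.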